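Trading a tert-butylphenyl triazole substituent for a benzyl one

This account rests on a few compounds, and the source may have more. Where it says the series, first, only, none or still open, it means among the compounds named here.

Compound 3 `CC(C)(C)c1ccc(-c2cn(CCC3(O)NC(=O)C(OCc4ccccc4)=C3OCc3ccccc3)nn2)cc1` reaches only the limit of a functional assay on HCT-116 cells (Homo sapiens) for antiproliferative activity, read by MTT assay, with a stated time of 24 h (on this read-out higher numbers stand for weaker inhibition and lower numbers for stronger inhibition), giving > 100000 nM; that figure is a limit, not a number. Compound 1 `O=C1NC(O)(CCn2cc(C3=CCCCC3)nn2)C(OCc2ccccc2)=C1OCc1ccccc1` likewise returns only a limit, > 100000 nM. Compound 2 `O=C1NC(O)(CCn2cc(-c3ccccc3)nn2)C(OCc2ccccc2)=C1OCc1ccccc1` gives a measured value, 53400 nM. Taken together, (the limit of > 100000 nM in this assay, at which 2 of the 3 values shown sit). The unmeasured compound 4 `O=C1NC(O)(CCn2cc(Cc3ccccc3)nn2)C(OCc2ccccc2)=C1OCc1ccccc1` differs from compound 3 by benzyl in place of 4-(tert-butyl)phenyl on an aromatic carbon. The measured steps that bear on this are an at least 1.8-fold higher number from compound 2 to compound 3 (0.27 log units; that floor lies within the scatter) and an at least 1.8-fold lower number from compound 1 to compound 2 (0.27 log units; that floor lies within the scatter); both are floors that lie within the scatter, so they give no readable direction. Compound 4 is therefore expected to land near the weak activity of the series, at roughly 70000 nM, within 25000 nM to 200000 nM. That corresponds to an expected at least 1.4-fold lower number from compound 3 to compound 4 (0.15 log units; that floor lies within the scatter).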

Compound 4, half-maximal inhibitory concentration: 51200 nM
Estimate against measurement, compound 4: 1.4-fold (0.14 log units) above, and the stated range covers the measured number.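

In this assay, benzyl and phenyl on this aromatic carbon of the five-membered aromatic ring are not told apart, with a 1.0-fold lower number from compound 2 to compound 4 (0.02 log units; within the scatter). Within the data shown here, this is the first comparison at this position between two measured numbers rather than against a limit. The steps of an at least 1.9-fold lower number from compound 3 to compound 4 (0.29 log units; that floor lies within the scatter) and an at least 1.9-fold lower number from compound 1 to compound 4 (0.29 log units; that floor lies within the scatter) are floors only, so neither shows a readable difference from benzyl: the limit of > 100000 nM in this assay, at which 2 of the 4 values shown sit.

Going by these compounds, whether any group at this carbon gives a step beyond the scatter stays open. A carboxylic acid or an amine on the benzyl ring, or a longer chain such as 2-phenylethyl, would test this.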